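A few compounds are considered here, and "the series" means these few. Any claim that something is new, unique, unknown or untested is made for them only; others in the source may bear on it.

Measured compounds in a functional assay on A-375 cells (Homo sapiens) for antiproliferative activity, read by MTT assay, with a stated time of 72 h; a lower number here means a stronger inhibitor, a higher number a weaker inhibitor:
compound 1, `COc1cccc(N2C(=O)COc3ccc(-c4cnc(Cl)c(NS(=O)(=O)c5ccc(F)cc5)c4)cc32)c1`: > 40000 nM, a limit of the assay.
compound 2, `O=C1COc2ccc(-c3cnc4ccccc4c3)cc2N1c1ccccc1`: > 40000 nM, a limit of the assay.
compound 3, `COc1cccc(N2C(=O)COc3ccc(-c4ccc(O)cc4)cc32)c1`: 30400 nM.

Compound 2 stands at the upper limit of this assay, not at a number, and it shares that position with compound 1 (the limit of > 40000 nM in this assay, at which 2 of the 3 values shown sit). For the measured compounds named here, compound 3 is the only compound of the three with a numeric value in this assay, and that value is 30400 nM. Going by the values given here, no pair of measured compounds differs in one place, so no measured step sets the scale for any change of the core of compound 2.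

The compound still to be measured is compound 4, `O=C1COc2ccc(-c3cnc4ccccc4c3)cc2N1C1CCCCC1`. It differs from compound 2 as follows: cyclohexyl in place of phenyl on an amide-type nitrogen in a ring.

Among the compounds with values here, with compound 2 only at a limit and no measured step to go by, the expected step from compound 2 to compound 4 in this assay is none beyond the scatter, a step that the limit leaves unreadable from compound 2 to compound 4, with a real chance that compound 4 again reports only a limit. For compound 4 the estimate in this assay is 45000 nM, expected to fall between 15000 nM and 150000 nM.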

Compound 4, half-maximal inhibitory concentration: > 40000 nM
Compound 4 ended at the assay's limit; the forecaster's own chance of this, stated with the estimate: 70%; the middle value is on the limit's open side.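

In this assay, compound 2 and compound 4 both report only a limit, so the step of cyclohexyl in place of phenyl on an amide-type nitrogen in a ring cannot be read: the limit of > 40000 nM in this assay, at which 3 of the 4 values shown sit.

The compounds shown leave open whether phenyl and cyclohexyl at this place differ in activity at all, as neither compound 2 nor compound 4 has a numeric value.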